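The compounds below may be only part of what the source reports. "The series", "measured", "known", "first", "only" and "open" are said of these compounds alone.

Measured in a physicochemical assay for solubility; on this read-out lower numbers stand for lower solubility and higher numbers for higher solubility:
Compound 1 `CNC(=O)c1cc(C(=O)NC2CC2)cn([C@H](C)c2ccccc2)c1=O` gives >= 168 ug/mL, a limit of the assay rather than a number.
Compound 2 `CNC(=O)c1cc(C(=O)NCCC(C)C)cn(Cc2ccccc2)c1=O` gives 10 ug/mL.
Compound 3 `CNC(=O)c1cc(C(=O)NC2CC2)cn(Cc2ccc(F)cc2)c1=O` gives >= 162 ug/mL, again a limit of the assay rather than a number.

Compound 3 therefore stands at the limit of >= 162 ug/mL in this assay, at which 1 of the 3 values shown sits, with no exact figure behind it. Compound 1 sits at the limit of >= 168 ug/mL in this assay, at which 1 of the 3 values shown sits. Of the three values shown, two are limits and only compound 2 has a read number, which lies well under both limits. The step from compound 1 to compound 3, a step that the two limits leave unreadable from compound 1 to compound 3, cannot be sized, since both of its ends are limits. For the measured compounds named here, compound 2 differs from compound 3 in the amide as well as in the group on the aromatic nitrogen, so no single step links it to compound 3.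

Compound 4 `CNC(=O)c1cc(C(=O)NC2CC2)cn(Cc2cccc3occc23)c1=O` is the next member. It differs from compound 3 as follows: 1-benzofuran-4-yl in place of 4-fluorophenyl on a saturated chain carbon bound to an aromatic nitrogen. Going by the values given here, none of the measured steps bears on this change, and the one step that shares the same place on the aromatic nitrogen is unreadable. Among the compounds with values here, the only guide is that compound 3 sits at a limit, so any move upward would not be seen. The expectation for compound 4 is a drop below the limit of compound 3, by a step of an at least 3.2-fold lower number from compound 3 to compound 4 (0.51 log units; beyond the scatter) in this assay, although the size is uncertain. The estimate for compound 4 is 50 ug/mL, expected to lie between 12 ug/mL and 165 ug/mL.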

Compound 4, solubility: >= 110 ug/mL
Compound 4: only a limit was reported; the forecaster's own chance of this, stated with the estimate: 25%; middle value at least 2.2-fold (0.34 log units) away from the limit.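

In this assay compound 4 gives >= 110 ug/mL, a limit of the assay and not a number. Compound 3 also stands at a limit, so no step can be read between compound 3 and compound 4. The compounds shown leave open whether 1-benzofuran-4-yl in place of 4-fluorophenyl changes the read-out at all, and by how much.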